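Imidazoline to imidazole on the dihydronaphthalene series

This account rests on a few compounds, and the source may have more. Where it says the series, first, only, none or still open, it means among the compounds named here.

For the measured compounds named here, compound 1 `C1=NCC(CC2=Cc3ccccc3CC2)N1` gives 398 nM in an assay on isolated protein for binding affinity to Adrenergic receptor alpha-1 (Rattus norvegicus), read by radioligand binding, in the presence of a further agent that is not named here (on this read-out higher numbers stand for weaker inhibition and lower numbers for stronger inhibition), the lower of the two numbers measured; compound 2 `COc1ccc2c(c1)C=C(CC1CN=CN1)CC2` gives 2510 nM, and the step of a 6.3-fold higher number from compound 1 to compound 2 (0.80 log units; beyond the scatter) is the only measured change in the set. Compound 3 `C1=C(Cc2c[nH]cn2)CCc2ccccc21` differs from compound 1 by a group of 5 heavy atoms (3 carbon, 2 nitrogen; one five-membered aromatic ring with 2 hetero atoms) in place of a group of 5 heavy atoms (3 carbon, 2 nitrogen; one five-membered non-aromatic ring with 2 hetero atoms), on a saturated chain carbon bound to a double-bonded ring carbon. Going by the values given here, no measured step touches this position, so the methoxy step offers no direct guide; the change is expected to raise the number in this assay by a 7.5-fold higher number from compound 1 to compound 3 (0.88 log units; beyond the scatter). Compound 3 is estimated at 3000 nM, with a range of 800 nM to 12000 nM.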

Compound 3, inhibition constant: 50.1 nM
The estimate for compound 3 lay 60-fold (1.78 log units) above the measured number; the whole stated range lies above it.
By their numbers in this assay, from the lowest: compound 3; then compound 1; then compound 2.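

The ring on the saturated chain carbon bound to a double-bonded ring carbon is open to change: in this assay, 1H-imidazol-4-yl in place of the non-aromatic ring gives a 7.9-fold lower number from compound 1 to compound 3 (0.90 log units; beyond the scatter) and moves the series toward stronger inhibition. For the compounds shown here, the methoxy step showed a change only on an aromatic carbon, so this is the first reading at this position. No available measurement bears on the origin of this shift.
Still open, going by these compounds, is whether methoxy on an aromatic carbon would raise the number on compound 3 as it does on compound 1. Also open, on these data alone, is how a longer chain carrying the 1H-imidazol-4-yl, or an amine in place of that ring, would read.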